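A few compounds are considered here, and "the series" means these few. Any claim that something is new, unique, unknown or untested is made for them only; others in the source may bear on it.

Compound 1 `Cc1cc(C)c(NC(=O)N(Cc2c[nH]c(-c3ccccc3)n2)C2CCCCCC2)c(C)c1` gives in a functional assay on a cell-free system (plasma) with sterol O-acyltransferase, Soat (Rattus norvegicus) as the target (a higher number here means that more compound is needed for the effect, a lower number that less compound is needed), a value of > 1 mg/kg, which is a limit of the assay and not a number. Compound 2 `Cc1cc(C)c(NC(=O)N(Cc2ccc(-c3n[nH]c(C)n3)cc2)C2CCCCCC2)c(C)c1` gives in this assay a value of > 1 mg/kg, likewise a limit. Compound 2 thus stands at the limit of > 1 mg/kg in this assay, at which 2 of the 2 values shown sit, and no number is known for it. Compound 3 `Cc1cc(C)c(NC(=O)N(Cc2ccc(N3CCN(C)CC3)cc2)C2CCCCCC2)c(C)c1` differs from compound 2 by 4-methylpiperazin-1-yl in place of 5-methyl-1H-1,2,4-triazol-3-yl on an aromatic carbon. Among the compounds with values here, with no measured step to lean on, the change from compound 2 to compound 3 is expected to be a step that the limit leaves unreadable from compound 2 to compound 3, nothing beyond the scatter. For compound 3 in this assay the estimate is 1.5 mg/kg, between 0.5 mg/kg and 5 mg/kg, most likely again reported only as a limit.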

Compound 3, dose for half-maximal effect: > 1 mg/kg
Compound 3 ended at the assay's limit; the forecaster's own chance of this, stated with the estimate: 70%; the middle value lies beyond the limit too.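

Within the data shown here, compound 2 and compound 3 both stand only at a limit in this assay, and no step between them can be read. The compounds shown leave open what dose any of them needs for half-maximal effect, and whether any substituent changes it: the limit of > 1 mg/kg in this assay, at which 3 of the 3 values shown sit.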